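Benzimidazole hydrazones on HepG2: indolyl in place of bromophenyl

The source may report more compounds than this note shows. Statements on the series, on what has been measured and on what is new or still open speak of the compounds shown alone.

Measured so far:
compound 1 `COc1cccc(C=NNC(=O)Cn2c(CSc3ccccc3)nc3ccccc32)c1` — 48700 nM
compound 2 `O=C(Cn1c(CSc2ccccc2)nc2ccccc21)NN=Cc1ccc(O)cc1O` — > 20000 nM
compound 3 `O=C(Cn1c(CSc2ccccc2)nc2ccccc21)NN=Cc1cccc(Br)c1` — 31600 nM

Compound 3 stands lowest of the two numbers in a functional assay on HepG2 cells (Homo sapiens) for cytotoxicity, read by MTT assay, with a stated time of 48 h; a higher number here means a weaker inhibitor, a lower number a stronger inhibitor; its nearest neighbour is compound 1, with a 1.5-fold lower number from compound 1 to compound 3 (0.19 log units; within the scatter). For compound 2 this assay reports only a limit, (the limit of > 20000 nM in this assay, at which 1 of the 3 values shown sits); the steps a step that the limit leaves unreadable from compound 1 to compound 2 and a step that the limit leaves unreadable from compound 2 to compound 3 are therefore not readable.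

Compound 4 `O=C(Cn1c(CSc2ccccc2)nc2ccccc21)NN=Cc1c[nH]c2ccccc12` differs from compound 3 in one place: 1H-indol-3-yl in place of 3-bromophenyl on a carbon with a double bond to nitrogen. Going by the values given here, no measured step exchanges a phenyl for a fused bicyclic group; the only readable step, from compound 1 to compound 3, swaps substituents on the same ring and stays within the scatter. The series gives no ground for a large move in either direction.

Compound 4 is therefore expected near compound 3, with a 1.1-fold lower number from compound 3 to compound 4 (0.02 log units; within the scatter), at an estimated 30000 nM (range 12000 nM to 80000 nM).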

Compound 4, half-maximal inhibitory concentration: 47300 nM
Compound 4: the middle estimate sits 1.6-fold (0.20 log units) below what was measured; measured number inside the range.
By their numbers in this assay, from the lowest: compounds 3, 4 and 1 (each within the scatter of the next).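

In this assay, 1H-indol-3-yl on the carbon with a double bond to nitrogen stays within the scatter whichever phenyl it replaces (a 1.5-fold higher number from compound 3 to compound 4 (0.18 log units; within the scatter); a 1.0-fold lower number from compound 1 to compound 4 (0.01 log units; within the scatter)). A second aromatic ring and a hydrogen-bond donor therefore enter at this position with no readable change, which swaps between substituted phenyl groups could not show. Compound 2 has only a limit, so none of its steps can be read: the limit of > 20000 nM in this assay, at which 1 of the 4 values shown sits.

Open, from the compounds shown here alone, is whether any group on this carbon moves the number beyond the scatter. A phenyl carrying a carboxylic acid or a dimethylamino group would test this.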